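The source may hold more compounds than are shown below. What is called first, only, known or untested is meant among the compounds shown, and "the series" means these compounds.

Measured so far in an assay on LtK cells with ATP-sensitive inward rectifier potassium channel 11 (Homo sapiens) as the target; on this read-out lower numbers stand for an effect already at smaller amounts and higher numbers for an effect only at larger amounts of compound:
- compound 1, `CC(=O)Nc1c(C(O)(C(F)(F)F)C(F)(F)F)ccc2ccccc12`: 18 nM
- compound 2, `CCC(=O)Nc1c(C(O)(C(F)(F)F)C(F)(F)F)ccc2ccccc12`: 15 nM

Compound 2 carries a propanoyl group on the amide nitrogen of the shared core; compound 1 carries an acetyl group there. In this assay compound 2 gives 15 nM, and compound 1 gives 18 nM. The two numbers sit within the usual scatter of each other: the step of a 1.2-fold lower number from compound 1 to compound 2 (0.08 log units; within the scatter) is small. So compound 2 is not separated from compound 1 on the numbers shown; the two stand together.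

Compound 3, `CC(C)C(=O)Nc1c(C(O)(C(F)(F)F)C(F)(F)F)ccc2ccccc12`, takes the chain one carbon further. The change is methyl in place of hydrogen on a saturated chain carbon bound to a carbonyl carbon and a saturated chain carbon; cut one bond further out, it reads ethyl to isopropyl, propanoyl to isopropylcarbonyl. Among the compounds with values here, the only measured step that bears on it is a 1.2-fold lower number from compound 1 to compound 2 (0.08 log units; within the scatter), which also added a methyl to a saturated chain carbon bound to the carbonyl carbon and stayed within the scatter. On that single precedent no step beyond the scatter is expected from compound 2 to compound 3: the expected step is no change at the digits printed from compound 2 to compound 3 (within the scatter). For compound 3 the estimate is 15 nM, with a range from 7 nM to 35 nM.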

Compound 3, half-maximal effective concentration: 6630 nM
The estimate for compound 3 lay 440-fold (2.65 log units) below the measured number; the measured number lies above the stated range.
By their numbers in this assay, from the lowest: compounds 2 and 1 (each within the scatter of the next); then compound 3.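

In this assay, the same exchange of methyl for hydrogen proved not to be interchangeable from one compound to the next: a 1.2-fold lower number from compound 1 to compound 2 (0.08 log units; within the scatter) stayed within the scatter, whereas a 440-fold higher number from compound 2 to compound 3 (2.65 log units; beyond the scatter) is large. The comparison with the acetyl compound gives the same picture, with a 370-fold higher number from compound 1 to compound 3 (2.57 log units; beyond the scatter), so acetyl and propanoyl stand together on the shared core while isopropylcarbonyl stands far apart from both, and the size of the step at this saturated chain carbon depends on what that carbon already carries. Nothing available accounts for this sharp break between the propanoyl and isopropylcarbonyl compounds.

The compounds shown leave open whether the jump goes with the branch on that carbon or with the number of carbons in the acyl group, a question that a longer straight chain such as butanoyl would address, while cyclopropylcarbonyl would show how the read-out responds when the two methyl groups of the branch are tied into a ring. They also leave open whether a tert-butylcarbonyl group would raise the number further or whether the step seen with isopropylcarbonyl is already the whole of the effect.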